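The compounds below may be only part of what the source reports. "The series", "measured", "known", "first", "only" and "open" are said of these compounds alone.

Compound 1 `NC(=O)C1CCN(c2nc(-c3cccnc3)nc3c2CN(Cc2ccccc2)CC3)CC1` was tested in an assay on cells with Cystic fibrosis transmembrane conductance regulator variant F508del (Homo sapiens) as the target, read by fluorescence, with stated times of 24 h and 30 min (a higher number here means that more compound is needed for the effect, a lower number that less compound is needed), where compound 1 gives 100000 nM. Compound 3 `CN(C)CCN1CCN(c2nc(-c3ccccn3)nc3c2CN(S(=O)(=O)c2ccccc2)CC3)CC1` gives 100000 nM, and these two numbers are level at the digits shown, together the highest of the three measured, so no order can be read between them. Compound 2 `C=CCc1cc(-c2sc(NC(=O)C(C)(C)C)nc2C)nn1C(=O)Nc1ccc(OC)cc1` gives 933 nM, a lower number than compound 1 by a gap that lies well beyond the scatter; compound 2 is built on a different scaffold, so it says nothing directly about the step at hand. Compound 4 `CN(C)CCN1CCN(c2nc(-c3cccnc3)nc3c2CN(Cc2ccccc2)CC3)CC1` differs from compound 1 in one place: 4-(2-(dimethylamino)ethyl)piperazin-1-yl in place of 4-carbamoylpiperidin-1-yl on an aromatic carbon. The same 4-(2-(dimethylamino)ethyl)piperazin-1-yl group is present in compound 3, which sits at the same number as compound 1 on the shared core. Among the measured compounds shown here, no measured pair isolates this change, so the expectation rests on compounds 1 and 3 alone, and the expected step from compound 1 to compound 4 is no change at the digits printed from compound 1 to compound 4 (within the scatter), none beyond the scatter. Compound 4 is accordingly estimated at 100000 nM, within a range from 30000 nM to 100000 nM.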

Compound 4, half-maximal effective concentration: 100000 nM
The estimate for compound 4 equals the measured number at the digits printed, and the stated range covers the measured number.
By their numbers in this assay, from the lowest: compound 2; then compounds 1, 3 and 4 (each within the scatter of the next).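

In this assay, placing 4-(2-(dimethylamino)ethyl)piperazin-1-yl in place of 4-carbamoylpiperidin-1-yl on an aromatic carbon gives no change at the digits printed from compound 1 to compound 4 (within the scatter). Among the compounds shown here, this is the first pair to isolate this position, with the pyridin-3-yl group and the rest of the shared core held the same, and it shows that exchanging these two groups leaves the number where it was, even though one brings a second ring hetero atom and the other carries the hydrogen-bond donor. Nothing measured here bears on why the two groups give the same number.

The compounds shown leave open whether any other group at this position, such as a morpholin-4-yl ring, a plain amine or a carboxylic acid on the piperidine ring, would give a different number on this core. They also leave open whether this position matters at all in this assay, as neither compound of the pair gives a number lower than the other.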